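A Methoxy Added Where Both Measured Values Sit at the Limit

This account rests on a few compounds, and the source may have more. Where it says the series, first, only, none or still open, it means among the compounds named here.

Compound 1 `CC(Oc1cccnc1Nc1cnn(C)c1)c1cccc(C(=O)NCc2ccccc2S(=O)(=O)C(C)C)c1` gives > 100000 nM in a functional assay on NCI-H3122 cells (Homo sapiens) for antiproliferative activity, read by MTT assay, with a stated time of 48 h (a lower number here means a stronger inhibitor, a higher number a weaker inhibitor), a limit of the assay rather than a number.
Compound 2 `COc1cccc(CNC(=O)c2cccc(C(C)Oc3ccnc(Nc4cnn(C)c4)c3)c2)c1` gives > 100000 nM in this assay, likewise a limit.

For the measured compounds named here, compound 2 therefore stands at the assay limit, and the one other value shown is a limit too: the limit of > 100000 nM in this assay, at which 2 of the 2 values shown sit. Compound 3 `COc1ccc(CNC(=O)c2cccc(C(C)Oc3ccnc(Nc4cnn(C)c4)c3)c2)cc1OC` differs from compound 2 by methoxy in place of hydrogen on an aromatic carbon. With both measured values at the limit, no step beyond the usual scatter is expected in this assay for this change. Compound 3 is expected to give about 100000 nM, within 30000 nM to 300000 nM, most likely again reported only as a limit. The expected step of a number no higher from compound 2 to compound 3 (the limit leaves the size open) is thus none beyond the scatter.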

Compound 3, half-maximal inhibitory concentration: 38500 nM
Compound 3: middle estimate off by 2.6-fold (0.41 log units), on the high side; low and high end bracket the measured number.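

The change from 3-methoxybenzyl to 3,4-dimethoxybenzyl is the only one shown that brings a value off the limit, with an at least 2.5-fold lower number from compound 2 to compound 3 (0.41 log units; beyond the scatter) in this assay. This shows that the position para to a large group can respond to a methoxy, even though compound 3 remains a weak inhibitor. The true size of the step stays unknown, as compound 2 is held at a limit: the limit of > 100000 nM in this assay, at which 2 of the 3 values shown sit.

Going by these compounds, whether a hydroxyl or an ethoxy at this carbon would lower the number further remains open. So does whether this methoxy would have the same effect without the neighbouring 3-methoxy group.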